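This account rests on a few compounds, and the source may have more. Where it says the series, first, only, none or still open, it means among the compounds named here.

Notes on the series in an ADME assay on 184B5 cells (Homo sapiens) for cytotoxicity, read by MTT assay, with a stated time of 72 h; on this read-out lower numbers stand for stronger inhibition of growth and higher numbers for weaker inhibition of growth. Compound 1 `CSc1nc(NCCCCCO)c2ccccc2n1` gives 49900 nM. Compound 2 `CCCCC[Se]c1nc(NCc2ccccc2)c2ccccc2n1` gives 70900 nM. Compound 3 `Sc1nc(NCc2ccccc2)c2ccccc2n1` gives 49600 nM. Among the measured compounds shown here, of these three numbers the one for compound 3 is the lowest, but the step of a 1.4-fold lower number from compound 2 to compound 3 (0.16 log units; within the scatter) sits within the scatter, and the numbers for compound 1 and compound 3 cannot be told apart within the scatter either, so no ordering among the three can be read from the numbers.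

Compound 4 `CSc1nc(NCc2ccccc2)c2ccccc2n1` has not yet been measured in this assay. It differs from compound 3 by methyl in place of hydrogen on a sulfur. For the measured compounds named here, no measured pair carries this same change. Going by the values given here, the only measured step at the same aromatic carbon, a 1.4-fold lower number from compound 2 to compound 3 (0.16 log units; within the scatter), swapped a much larger group for the sulfur and stayed within the scatter. Compound 1 already carries the methylsulfanyl group that compound 4 will carry, and compound 1 gives 49900 nM, which is not separable within the scatter from compound 3. Nothing in the numbers therefore points to a shift beyond the scatter in either direction. The expected step of a 1.0-fold higher number from compound 3 to compound 4 (0.00 log units; within the scatter) is accordingly flat. The estimate for compound 4 in this assay is 50000 nM, with a range from 20000 nM to 125000 nM.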

Compound 4, concentration for 50% growth inhibition: 28900 nM
Estimate against measurement, compound 4: 1.7-fold (0.24 log units) above, within the range that was stated.
By their numbers in this assay, from the lowest: compounds 4, 3, 1 and 2 (each within the scatter of the next, the first and the last beyond it).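

In this assay, the change from hydrogen to methyl on the sulfur can now be read directly: a 1.7-fold lower number from compound 3 to compound 4 (0.23 log units; within the scatter) shows that this small addition does not separate from the scatter. Among the compounds shown here, the group on the aromatic carbon gives the only step that lies beyond the scatter, a 2.5-fold lower number from compound 2 to compound 4 (0.39 log units; beyond the scatter), whereas the sulfanyl compound gave only a 1.4-fold lower number from compound 2 to compound 3 (0.16 log units; within the scatter), so methylsulfanyl at this place separates modestly from the selenium-bearing group of 6 heavy atoms while sulfanyl does not. For the compounds shown here, the other place can also be read for the first time, and phenyl in place of 4-hydroxybutyl on the saturated chain carbon bound to a nitrogen gives a 1.7-fold lower number from compound 1 to compound 4 (0.24 log units; within the scatter), a step that stays within the scatter.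

No measurement at hand bears on what lies behind the size of these steps.

Compound 2 differs from compound 4 in both the chalcogen atom and the chain, so a methyl on selenium or a pentyl on sulfur would be needed to separate those two parts. On these data alone, it also remains open how an ethyl or butyl chain on the sulfur, or a chain ending in an amine or a carboxylic acid, would read here.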